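Moving a halogen around the outer phenyl ring

The compounds below may be only part of what the source reports. "The series", "measured", "known", "first", "only" and "open" are said of these compounds alone.

In an assay on tissue (MDA-MB-231 cells) for inhibition of Indoleamine 2,3-dioxygenase 1 (Homo sapiens), read by spectrophotometry, with stated times of 4 h and 5 h (on this read-out higher numbers stand for weaker inhibition and lower numbers for stronger inhibition), compound 2 `O=[N+]([O-])c1ccc(N/C(=N\O)c2ccccc2Br)c2nonc12` gives 66 nM, while compound 1 `O=[N+]([O-])c1ccc(N/C(=N\O)c2ccccc2F)c2nonc12` gives 131 nM, and the step of a 2.0-fold lower number from compound 1 to compound 2 (0.30 log units; within the scatter) lies within the scatter. Compound 3 `O=[N+]([O-])c1ccc(N/C(=N\O)c2cccc(F)c2)c2nonc12` differs from compound 2 by 3-fluorophenyl in place of 2-bromophenyl on a carbon with a double bond to nitrogen. Going by the values given here, the only measured step swaps fluoro for bromo and leaves the halogen where it was, so nothing measured here tells how changing the halogen's position affects the number. The expected step is therefore a 1.8-fold higher number from compound 2 to compound 3 (0.26 log units; within the scatter), not beyond the scatter. The estimate for compound 3 is 120 nM, with a range from 40 nM to 400 nM.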

Compound 3, half-maximal inhibitory concentration: 245 nM
Compound 3: the middle estimate sits 2.0-fold (0.31 log units) below what was measured; measured number inside the range.
By their numbers in this assay, from the lowest: compounds 2, 1 and 3 (each within the scatter of the next, the first and the last beyond it).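

In this assay, going by these compounds alone, the first step beyond the scatter is a 3.7-fold higher number from compound 2 to compound 3 (0.57 log units; beyond the scatter) with 3-fluorophenyl in place of 2-bromophenyl, but this step changes both the halogen and its position. With fluoro kept and only its position changed, the result is a 1.9-fold higher number from compound 1 to compound 3 (0.27 log units; within the scatter) and so shows no clear effect of position alone. No measured evidence is available to explain these numbers.

On these data alone, it remains open how much of the larger step comes from losing bromo and how much from the new position. As far as these compounds go, the effect of chloro, an amine or a carboxylic acid on this phenyl ring also remains open.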